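A few compounds are considered here, and "the series" means these few. Any claim that something is new, unique, unknown or untested is made for them only; others in the source may bear on it.

Compound 3 `CCC(CC)O[C@@H]1C=C(C(=O)O)C[C@H](NCc2ccc(Sc3cccs3)cc2)[C@H]1NC(C)=O` gives > 200000 nM in an ADME assay on cells (Fibroblast, Gallus gallus) for cytotoxicity, read by CCK-8 assay, with a stated time of 48 h (on this read-out lower numbers stand for higher toxicity in this test and higher numbers for lower toxicity in this test), and this is a limit of the assay, not a number. Compound 1 `CCc1ccc(CN[C@H]2CC(C(=O)O)=C[C@@H](OC(CC)CC)[C@@H]2NC(C)=O)cc1` gives > 200000 nM, which is also a limit. Compound 2 `CCC(CC)O[C@@H]1C=C(C(=O)O)C[C@H](NCc2ccc(C(C)(C)C)cc2)[C@H]1NC(C)=O` gives > 200000 nM, again a limit. The series therefore stands at the limit of > 200000 nM in this assay, at which 3 of the 3 values shown sit.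

Compound 4 `CCC(CC)O[C@@H]1C=C(C(=O)O)C[C@H](NCc2ccc(-c3ccc(SC)cc3)cc2)[C@H]1NC(C)=O` carries 4-(methylsulfanyl)phenyl in place of (thiophen-2-yl)sulfanyl on an aromatic carbon, para to a large group: 4-(methylsulfanyl)phenyl in place of (thiophen-2-yl)sulfanyl on an aromatic carbon.

For the measured compounds named here, three measured steps bear on this change, since each alters the group at this place: a step that the two limits leave unreadable from compound 1 to compound 2, a step that the two limits leave unreadable from compound 1 to compound 3 and a step that the two limits leave unreadable from compound 2 to compound 3. Going by the values given here, none has a readable size, so the only guide they leave is that ethyl, tert-butyl and (thiophen-2-yl)sulfanyl all end at the same limit in this assay. No change beyond the usual scatter is expected, in either direction. The estimated step is a number no higher from compound 3 to compound 4 (the limit leaves the size open). For compound 4 the expected value is 200000 nM, with an estimated range from 100000 nM to 400000 nM, and the assay will most likely report only a limit again.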

Compound 4, half-maximal cytotoxic concentration: > 200000 nM
Compound 4 gave a limit, no number (the forecaster's own chance of this, stated with the estimate: 85%); the middle value lies on the limit itself.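

Compound 4 ends at a limit in this assay, not at a number, and so do compound 1, compound 2 and compound 3, so no step to compound 4 can be read: the limit of > 200000 nM in this assay, at which 4 of the 4 values shown sit.

As far as these compounds go, what stays open is where the true values of these four compounds lie past that limit, and whether they differ from one another at all.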